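Replacing the group on the carbonyl carbon of compound 1

A few compounds are considered here, and "the series" means these few. Any claim that something is new, unique, unknown or untested is made for them only; others in the source may bear on it.

In an ADME assay on microsomes from liver (Homo sapiens) for metabolic stability, read by LC-MS, with a stated time of 30 min, tested at 1 uM (a lower number here means that less of the compound is left, a higher number that more of the compound is left), compound 1 (`O=C(NCc1ccc(S(=O)(=O)c2ccccc2)cc1)c1cc2ccncc2s1`) stands at 48% and compound 2 (`O=C(NCc1ccc(S(=O)(=O)c2ccccc2C(F)(F)F)cc1)c1cc2cnccc2[nH]1`) at 52% so these two lie within the scatter of each other. Compound 3 (`O=C(NCc1ccc(S(=O)(=O)c2ccccc2)cc1)c1cc(-c2cccnc2)[nH]n1`) stands at 67% which is higher than compound 1 by more than the scatter. Compound 1 therefore belongs to the lower pair of the three.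

Compound 4 (`O=C(NCc1ccc(S(=O)(=O)c2ccccc2)cc1)c1ccc2nncn2c1`) keeps the rest of compound 1 and changes only the group on the carbonyl carbon (a group of 9 heavy atoms (6 carbon, 3 nitrogen; one five-membered aromatic ring with 3 hetero atoms, one six-membered aromatic ring with 1 hetero atom) in place of a group of 9 heavy atoms (7 carbon, 1 nitrogen, 1 sulfur; one five-membered aromatic ring with 1 hetero atom, one six-membered aromatic ring with 1 hetero atom), on a carbonyl carbon). For the measured compounds named here, no two measured compounds in this set form a step that differs in one place, so no measured step gives a size for this change. The values in hand offer only a loose frame, with compound 1 at 48% and compound 3 at 67%. A small upward move that stays within the scatter is expected in this assay (a number 7 percentage points higher from compound 1 to compound 4 (within the scatter)). Going by the values given here, the range is kept wide since no measured compound carries the entering group. The estimate for compound 4 is 55% with 37% to 75% as its expected range.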

Compound 4, percent of the compound remaining: 96%
For compound 4 the middle estimate is 41 percentage points below the measured one, outside the stated range (above it).
By their numbers in this assay, from the lowest: compounds 1 and 2 (each within the scatter of the next); then compound 3; then compound 4.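

In this assay, the group on the carbonyl carbon is now shown to have a strong hold on the read-out, with the exchange giving a number 48 percentage points higher from compound 1 to compound 4 (beyond the scatter), a large step and the only one in the series that can be read at a single place. The step comes with no change in size by heavy-atom count, since the leaving and entering groups each have 9 heavy atoms; what differs is the atom make-up, with 3 nitrogen and no sulfur in the entering group against 1 nitrogen and 1 sulfur in the leaving one, and a five-membered aromatic ring with 3 hetero atoms in place of one with 1 hetero atom. No measurement at hand accounts for the size of this step.

With one step, the contributions of the loss of sulfur, the added nitrogen and the extra hydrogen-bond acceptor cannot be told apart. Also open, as far as these compounds go, is whether the entering group keeps this result with a methyl group or an amine added to it, or with a trifluoromethyl group on the phenyl sulfone part of the molecule.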